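Oxadiazoline series: swapping the aryl group on the saturated ring carbon

This account rests on a few compounds, and the source may have more. Where it says the series, first, only, none or still open, it means among the compounds named here.

Three compounds of this set have numbers in a functional assay on BGC-823 cells (Homo sapiens) for antiproliferative activity, read by MTT assay, tested at 5 uM; on this read-out lower numbers stand for a weaker effect and higher numbers for a stronger effect at the one concentration tested. Compound 1 `COc1cc(C(=O)N/N=C/c2ccc(C(F)(F)F)cc2)cc(OC)c1OC` gives 56.3% in this assay. Compound 2 `COc1cc(C2=NN(C(C)=O)C(c3ccccc3F)O2)cc(OC)c1OC` gives 32.8%, which stands second highest of the three, with compound 1 a number higher by an amount beyond the scatter and compound 3 a number lower by an amount beyond the scatter. Compound 3 `COc1cc(C2=NN(C(C)=O)C(c3cc(OC)c(OC)c(OC)c3)O2)cc(OC)c1OC` gives -1.4% in this assay.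

Compound 4 `COc1cc(C2=NN(C(C)=O)C(c3cccc(C(F)(F)F)c3)O2)cc(OC)c1OC` has not been measured. Against compound 2 its change is 3-(trifluoromethyl)phenyl in place of 2-fluorophenyl on a saturated ring carbon. Among the compounds with values here, no step between two measured compounds mirrors this change, so the size of the step can only be guessed. Compound 1, which also carries a trifluoromethyl on its phenyl, gives 56.3%, and the aryl-bearing compounds with a trimethoxyphenyl at the same place, compound 3, give -1.4%; against that spread a small rise is expected for compound 4 in this assay, with the step of a number 7.2 percentage points higher from compound 2 to compound 4 (within the scatter) likely within or just beyond the scatter. Compound 4 is therefore estimated at 40%, in the range 20% to 60%.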

Compound 4, a percentage reported as inhibition, at one concentration (the size of the read-out at that concentration, not a potency): 41.1%
Compound 4: the middle estimate sits 1.1 percentage points below what was measured, and the stated range covers the measured number.
By their numbers in this assay, from the lowest: compound 3; then compounds 2 and 4 (each within the scatter of the next); then compound 1.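

In this assay, within the data shown here, the pair gives the one readable step at this saturated ring carbon, a number 8.3 percentage points higher from compound 2 to compound 4 (within the scatter) for 3-(trifluoromethyl)phenyl in place of 2-fluorophenyl, so these two compounds cannot be told apart at the one concentration tested. The position thus tolerates both fluorine-bearing phenyl groups, while compound 3 gives -1.4% with its trimethoxyphenyl at the same place. No measurement on hand bears on why compound 2 and compound 4 read alike.

Compound 2 and compound 4 differ in both the fluorine-bearing substituent and its place on the phenyl, and the two contributions remain unseparated. Also open, going by these compounds, is how an unsubstituted phenyl, or a phenyl carrying a chlorine, a nitrile or an amine, would read on this carbon.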